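Cyclopropyl for ethyl on the shared core, fluoro arm kept

This account rests on a few compounds, and the source may have more. Where it says the series, first, only, none or still open, it means among the compounds named here.

Of the compounds shown here, two have numbers so far. Compound 1 `Cn1c(C2CC2)nc2ccc(-n3ccc(OCc4ccc(Cl)cc4)cc3=O)cc21` gives 35 nM in an assay on CHO cells for displacement of a labelled ligand from melanin-concentrating hormone receptor 1 (Homo sapiens), read by scintillation counting, with a stated time of 1 h; on this read-out higher numbers stand for weaker inhibition and lower numbers for stronger inhibition. Compound 2 `CCc1nc2ccc(-n3ccc(OCc4ccc(F)cc4)cc3=O)cc2n1C` gives 48 nM in this assay, the higher of the two numbers, though its nearest neighbour, compound 1, lies within the scatter, so the two are not told apart. Compound 3 `Cn1c(C2CC2)nc2ccc(-n3ccc(OCc4ccc(F)cc4)cc3=O)cc21` is not yet measured. It differs from compound 2 in one place: cyclopropyl in place of ethyl on an aromatic carbon of the five-membered aromatic ring of the fused system, between two ring nitrogen atoms. Compound 1 already carries the cyclopropyl group together with a chloro arm and sits where compound 2 does, so no step beyond the scatter is expected from this exchange in this assay. Compound 3 is therefore estimated at 40 nM in this assay, within a range from 18 nM to 90 nM. The expected change from compound 2 to compound 3 is a 1.2-fold lower number from compound 2 to compound 3 (0.08 log units; within the scatter), essentially flat.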

Compound 3, half-maximal inhibitory concentration: 40 nM
Beside the measured number, compound 3's estimate shows no gap at the digits printed; low and high end bracket the measured number.
By their numbers in this assay, from the lowest: compounds 1, 3 and 2 (each within the scatter of the next).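

In this assay, among these compounds, cyclopropyl in place of ethyl on the aromatic carbon between two ring nitrogen atoms, with the fluoro arm kept, gives a 1.2-fold lower number from compound 2 to compound 3 (0.08 log units; within the scatter) and so provides the first direct reading at this position: the two groups are not told apart here. The arm can now be read on its own as well, since fluoro in place of chloro on an aromatic carbon, with cyclopropyl kept, gives a 1.1-fold higher number from compound 1 to compound 3 (0.06 log units; within the scatter) and again shows no step beyond the scatter. Nothing available offers an explanation for either flat step.

These compounds leave open how far this position tolerates other groups, such as a longer chain, an amine or a phenyl ring. They also leave open whether a methoxy group on the arm, or no halogen at all, would shift the number.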